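Replacing a fluorophenyl arm with a dimethoxyphenyl arm

This account rests on a few compounds, and the source may have more. Where it says the series, first, only, none or still open, it means among the compounds named here.

Of the compounds shown here, three sharing one core have been measured in a functional assay on A549 cells (Homo sapiens) for cytotoxicity, read by MTT assay, with a stated time of 48 h; on this read-out lower numbers stand for stronger inhibition and higher numbers for weaker inhibition. For the measured compounds named here, compound 1 `COc1ccc(-c2cc(C(=O)Nc3nc4ccc(Cl)cc4s3)nc3cc(-c4ccccc4)nn23)cc1OC` gives 6160 nM, and compound 2 `COc1ccc(-c2cc(C(=O)Nc3nc4ccc(F)cc4s3)nc3cc(-c4ccccc4)nn23)cc1OC` gives 6910 nM; the only single-change comparison available, a 1.1-fold higher number from compound 1 to compound 2 (0.05 log units; within the scatter), is a swap of one small atom for another that leaves the read-out essentially unmoved. Compound 3 `Cc1cc2nc(NC(=O)c3cc(-c4ccc(F)cc4)n4nc(-c5ccccc5)cc4n3)sc2cc1C` gives 12600 nM, the high end of the three numbers: its gap to compound 1 is beyond the scatter, while its gap to compound 2 is within it.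

Compound 4 `COc1ccc(-c2cc(C(=O)Nc3nc4cc(C)c(C)cc4s3)nc3cc(-c4ccccc4)nn23)cc1OC` differs from compound 3 by 3,4-dimethoxyphenyl in place of 4-fluorophenyl on an aromatic carbon. Going by the values given here, no measured pair isolates this exact change, because compounds 1 and 2, which carry the same dimethoxyphenyl arm, also differ from compound 3 elsewhere. Compound 1 gives 6160 nM and compound 2 gives 6910 nM, both somewhat lower than the number of compound 3. A modest drop in number is therefore expected, with the step of a 1.6-fold lower number from compound 3 to compound 4 (0.20 log units; within the scatter) likely near the edge of the scatter. For compound 4 the expected value in this assay is 8000 nM, with a range from 3500 nM to 18000 nM.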

Compound 4, half-maximal inhibitory concentration: 2950 nM
The estimate for compound 4 lay 2.7-fold (0.43 log units) above the measured number, outside the stated range (below it).
By their numbers in this assay, from the lowest: compound 4; then compounds 1, 2 and 3 (each within the scatter of the next, the first and the last beyond it).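

In this assay, for the compounds shown here, the change from 4-fluorophenyl to 3,4-dimethoxyphenyl on the aromatic carbon of the shared core lowers the number (a 4.3-fold lower number from compound 3 to compound 4 (0.63 log units; beyond the scatter)), showing for the first time that the group at this position can move the read-out beyond the scatter. With 3,4-dimethoxyphenyl held constant, 5,6-dimethyl-1,3-benzothiazol-2-yl on the amide-type nitrogen also gives a lower number than 6-fluoro-1,3-benzothiazol-2-yl (a 2.3-fold lower number from compound 2 to compound 4 (0.37 log units; beyond the scatter)) and 6-chloro-1,3-benzothiazol-2-yl (a 2.1-fold lower number from compound 1 to compound 4 (0.32 log units; beyond the scatter)), so that end of the molecule matters too, although swapping chloro for fluoro had not shown this. Nothing available explains why either change lowers the number. The compounds shown leave open whether both methoxy groups are needed. A phenyl arm carrying a single methoxy group, a hydroxyl or an amine could settle that.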